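A few compounds are considered here, and "the series" means these few. Any claim that something is new, unique, unknown or untested is made for them only; others in the source may bear on it.

In a functional assay on MCF7 cells (Homo sapiens) for antiproliferative activity, read by MTT assay, with a stated time of 48 h (on this read-out lower numbers stand for stronger inhibition and higher numbers for weaker inhibition), compound 1 (`COc1ccc(-c2c(Nc3ccc(F)cc3)c3ccccc3oc2=O)cc1`) gives 38500 nM as its half-maximal value. Compound 2 (`COc1ccc(-c2c(Nc3ccc(F)cc3)c3ccc(OC)cc3oc2=O)cc1`) reads > 100000 nM in this assay and that is a limit, not a number. Compound 3 (`COc1ccc2c(Nc3ccc(F)cc3)c(C(=O)C(F)(F)F)c(=O)oc2c1`) differs from compound 2 by (trifluoromethyl)carbonyl in place of 4-methoxyphenyl on an aromatic carbon with (trifluoromethyl)carbonyl in place of 4-methoxyphenyl on an aromatic carbon. For the measured compounds named here, the only measured step is an at least 2.5-fold higher number from compound 1 to compound 2 (0.41 log units; beyond the scatter) for methoxy in place of hydrogen on an aromatic carbon. It does not touch this group and sets no firm size here. A modest move to a lower number in this assay is expected, though another limit reading could occur. The expected step is an at least 2.5-fold lower number from compound 2 to compound 3 (0.39 log units; beyond the scatter) as estimated. For compound 3 the estimated value is 40000 nM with an expected range from 8000 nM to 100000 nM in this series.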

Compound 3, half-maximal inhibitory concentration: 9740 nM
Estimate against measurement, compound 3: 4.1-fold (0.61 log units) above; the measured number falls inside the stated range.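

For the compounds shown here, this is the first change at the aromatic carbon ortho to the (4-fluorophenyl)amino group, and in this assay (trifluoromethyl)carbonyl in place of 4-methoxyphenyl gives an at least 10-fold lower number from compound 2 to compound 3 (1.01 log units; beyond the scatter). The read-out therefore responds to the group at this position, and a 4-methoxyphenyl group is not needed there for a measurable value. Compound 2 reads > 100000 nM, which is a limit of the assay and not a number.

On these data alone, whether the drop follows the carbonyl or the trifluoromethyl remains open; an acetyl group or a carboxylic acid here would separate them. Also open, as far as these compounds go, is whether the same exchange holds on the core of compound 1.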